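Triazole series, cytotoxicity on B16 cells: towards compound 4

The source may hold more compounds than are shown below. What is called first, only, known or untested is meant among the compounds shown, and "the series" means these compounds.

Measured so far in a functional assay on B16 cells (Mus musculus) for cytotoxicity, read by MTT assay, with a stated time of 48 h; a lower number here means a stronger inhibitor, a higher number a weaker inhibitor:
compound 1 `OCCCn1cc(-c2ccc(C(F)(F)F)cc2)nn1` gives > 100000 nM, a limit of the assay.
compound 2 `CCOC(=O)Cn1cc(-c2ccc3ccccc3c2)nn1` gives > 100000 nM, a limit of the assay.
compound 3 `CC1(C)OC[C@H](Cn2cc(-c3ccc(C(F)(F)F)cc3)nn2)O1` gives > 100000 nM, a limit of the assay.

Compound 1 thus stands only at a limit; no number is known for it, and the same holds for the other two, all three sitting at the limit of > 100000 nM in this assay, at which 3 of the 3 values shown sit. Compound 4 `COc1ccc(-c2cn(CCCO)nn2)cc1` differs from compound 1 by methoxy in place of trifluoromethyl on an aromatic carbon. Going by the values given here, the one measured step in this set, a step that the two limits leave unreadable from compound 1 to compound 3, changes the chain on the aromatic nitrogen rather than the aromatic ring, and its size cannot be read since both of its values sit at the limit of > 100000 nM in this assay, at which 3 of the 3 values shown sit. Among the compounds with values here, no measured step touches the group on the six-membered carbon ring, so nothing here points to a step in this assay beyond the scatter, in either direction. Compound 4 is therefore expected to return a limit again, estimated around 100000 nM, range 30000 nM to 300000 nM. The step expected from compound 1 to compound 4 is a number no higher from compound 1 to compound 4 (the limit leaves the size open).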

Compound 4, half-maximal inhibitory concentration: > 100000 nM
Compound 4 was reported as a limit (the forecaster's own chance of this, stated with the estimate: 85%); the middle value lies on the limit itself.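

No new step can be read between compound 1 and compound 4, since both sit at a limit: the limit of > 100000 nM in this assay, at which 4 of the 4 values shown sit.

Whether methoxy in place of trifluoromethyl changes cytotoxicity at all stays open, and none of the compounds shown gives a number.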